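A Fluorobenzyl Amide Set Against Its Benzyl and Propyl Kin

A few compounds are considered here, and "the series" means these few. Any claim that something is new, unique, unknown or untested is made for them only; others in the source may bear on it.

Compound 1 `C=CC1=C(C(=O)NCc2ccc(C)cc2)C(c2ccc(OC)cc2)OC1`: 15900 nM
Compound 2 `C=CC1=C(C(=O)Nc2ccccc2)C(c2ccc(OC)cc2)OC1`: > 100000 nM
Compound 3 `C=CC1=C(C(=O)NCCC)C(c2ccc(OC)cc2)OC1`: 14000 nM

In a functional assay on HeLa cells (Homo sapiens) for cytotoxicity, read by MTT assay, with a stated time of 24 h (on this read-out higher numbers stand for weaker inhibition and lower numbers for stronger inhibition), compound 3 gives 14000 nM, and compound 1 gives 15900 nM; the two sit within the scatter of each other, so compound 3 shares the lower end of the numbers with compound 1. For compound 2 the reported value is a limit of this assay, not a number (the limit of > 100000 nM in this assay, at which 1 of the 3 values shown sits). The step of a 1.1-fold lower number from compound 1 to compound 3 (0.06 log units; within the scatter) swapped the group at the same place that is changed here and stayed within the scatter, whereas an at least 6.2-fold higher number from compound 1 to compound 2 (0.79 log units; beyond the scatter) and an at least 7.1-fold lower number from compound 2 to compound 3 (0.85 log units; beyond the scatter) replaced the whole group on the amide-type nitrogen and were larger.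

Compound 4 `C=CC1=C(C(=O)NCc2ccccc2F)C(c2ccc(OC)cc2)OC1` differs from compound 3 by 2-fluorophenyl in place of ethyl on a saturated chain carbon bound to an amide-type nitrogen. Given the flat step between compound 1 and compound 3, the step of no change at the digits printed from compound 3 to compound 4 (within the scatter) is expected to remain within the scatter. Compound 4 is therefore estimated at 14000 nM, between 6000 nM and 35000 nM.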

Compound 4, half-maximal inhibitory concentration: > 100000 nM
Compound 4: no number, only a limit; the forecaster's own chance of this, stated with the estimate: 10%; middle value at least 7.1-fold (0.85 log units) from the limit.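

Ethyl and 4-methylphenyl on a saturated chain carbon bound to an amide-type nitrogen had stayed within the scatter of each other, yet 2-fluorophenyl there gives an at least 7.1-fold higher number from compound 3 to compound 4 (0.85 log units; beyond the scatter) and an at least 6.2-fold higher number from compound 1 to compound 4 (0.79 log units; beyond the scatter). Since compound 1 also carries a six-membered aromatic ring at this place, having such a ring there does not alone separate these results. Compound 4 stands at a limit of this assay, not a number, and the step involving compound 2, also a limit, cannot be read: the limit of > 100000 nM in this assay, at which 2 of the 4 values shown sit.

As far as these compounds go, it remains open whether the fluorine or its ring position matters, which a plain benzyl or 2-methylbenzyl group would test.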